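The source may hold more compounds than are shown below. What is called first, only, known or untested is meant among the compounds shown, and "the series" means these compounds.

Working notes on the series, read in a functional assay on DU-145 cells (Homo sapiens) for inhibition, read by trypan blue exclusion, with a stated time of 72 h; a lower number here means a stronger inhibitor, a higher number a weaker inhibitor. Compound 1 `Cn1c(=O)c(S(=O)(=O)c2ccc(Cl)cc2Cl)cc2cnc(Nc3ccc4[nH]ccc4c3)nc21` gives 1000 nM, and compound 2 `O=c1c(S(=O)(=O)c2ccc(F)cc2F)cc2cnc(Nc3ccc4[nH]ccc4c3)nc2n1C1CCCC1` gives 5000 nM. Compound 1 therefore stands at the lower of the two numbers, the stronger inhibitor of the pair, with a gap beyond the scatter.

Within the data shown here, no pair of measured compounds differs in one place only, so the series offers no direct reading of any single change.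

Compound 3 `Cn1c(=O)c(S(=O)(=O)c2ccc(Cl)cc2)cc2cnc(Nc3ccc4[nH]ccc4c3)nc21` is the next point to read against compound 1. The change is hydrogen in place of chloro on an aromatic carbon, ortho to a large group and meta to a chloro group, taking 2,4-dichlorophenyl to 4-chlorophenyl. The other chloro group and the shared core stay as they are.

Among the measured compounds shown here, with no measured precedent, only a modest effect is assumed, leaning toward a weaker inhibitor. The expected size is a 1.5-fold higher number from compound 1 to compound 3 (0.18 log units; within the scatter), which is estimated to stay within the scatter, though a larger move cannot be excluded.

For compound 3 the estimated value is 1500 nM, with an expected range of 500 nM to 4500 nM.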

Compound 3, half-maximal inhibitory concentration: 250 nM
Estimate against measurement, compound 3: 6.0-fold (0.78 log units) above, and the stated range ends above it.
By their numbers in this assay, from the lowest: compound 3; then compound 1; then compound 2.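

Read in this assay, the step of a 4.0-fold lower number from compound 1 to compound 3 (0.60 log units; beyond the scatter) is the first reading of a single change in the series: hydrogen in place of chloro on an aromatic carbon, ortho to a large group and meta to a chloro group. It shows that the chloro group at this position is not required for inhibition in this cell read-out, and that, of the two groups read here, the 4-chlorophenyl compound with hydrogen gives the lower number. No measurement on hand accounts for this step, so the reading stands as an observation only.

Among these compounds, only chloro and hydrogen have been read at this position, so the standing of a fluoro group, a methyl group, a methoxy group or an amine there remains open, as does the contribution of the remaining chloro group, which has no step of its own. Compound 2 differs from both compound 1 and compound 3 in more than one place, so it cannot show whether the same step would hold with a cyclopentyl group in place of the methyl group.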